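The source may hold more compounds than are shown below. What is called first, only, known or untested is meant among the compounds shown, and "the series" means these compounds.

Measured so far:
compound 1 `CCN1CCN(c2cc(C)c3cc(NC(=O)c4ccc(Cl)c(Cl)c4)ccc3n2)CC1` — 1380 nM
compound 2 `Cc1cc(N2CCCC2)nc2ccc(NC(=O)c3ccc(Cl)c(Cl)c3)cc12` — 26300 nM

Compound 2 stands highest of the two numbers in a functional assay on MCF7 cells (Homo sapiens) for antiproliferative activity, read by MTT assay, with a stated time of 72 h; on this read-out higher numbers stand for weaker inhibition and lower numbers for stronger inhibition; its nearest neighbour is compound 1, with a far lower number. Among the compounds with values here, the one step measured in this assay is a 19-fold higher number from compound 1 to compound 2 (1.28 log units; beyond the scatter), and it shows that an exchange of the amine on this aromatic carbon of the shared core can move the number a long way.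

Compound 3 `CCNc1cc(C)c2cc(NC(=O)c3ccc(Cl)c(Cl)c3)ccc2n1` is the next compound to be measured. It differs from compound 2 by ethylamino in place of pyrrolidin-1-yl on an aromatic carbon. The step from compound 1 to compound 2 bears on it only in that it concerns the same position; it does not tell which way an ethylamino group will go. Within the data shown here, with only that one large step as guidance, the expected shift for compound 3 in this assay is a 1.8-fold lower number from compound 2 to compound 3 (0.24 log units; within the scatter), a modest step that may well lie within the scatter, with some lean towards a lower number than compound 2. Compound 3 is therefore estimated at 15000 nM, with a range of 4000 nM to 60000 nM.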

Compound 3, half-maximal inhibitory concentration: 48600 nM
The estimate for compound 3 lay 3.2-fold (0.51 log units) below the measured number; the range from low to high includes it.
By their numbers in this assay, from the lowest: compound 1; then compounds 2 and 3 (each within the scatter of the next).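

In this assay, exchanging the ring of pyrrolidin-1-yl for the open chain of ethylamino, which also adds a hydrogen-bond donor, gives a 1.8-fold higher number from compound 2 to compound 3 (0.27 log units; within the scatter), so on this aromatic carbon next to the ring nitrogen these two groups cannot be told apart. Ethylamino in place of 4-ethylpiperazin-1-yl gives a 35-fold higher number from compound 1 to compound 3 (1.55 log units; beyond the scatter), a second large step at this position, and among these three compounds only compound 1, with 4-ethylpiperazin-1-yl, stands clearly apart, while compound 2 and compound 3 share the weak end of the series. No supporting measurement bears on why the numbers fall this way.

Going by these compounds, it remains open which part of 4-ethylpiperazin-1-yl goes with the lower number of compound 1: the six-membered ring, its second nitrogen or the ethyl group on that nitrogen. Comparing piperazin-1-yl, 4-methylpiperazin-1-yl, morpholin-4-yl or a chain such as 2-(dimethylamino)ethylamino at this position on the shared core would begin to separate these parts.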